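The source may report more compounds than this note shows. Statements on the series, on what has been measured and on what is new or still open speak of the compounds shown alone.

Going by the values given here, in an assay on cells for inhibition of histone-lysine N-methyltransferase EZH2 (Homo sapiens), read by ELISA, with a stated time of 72 h (a lower number here means a stronger inhibitor, a higher number a weaker inhibitor), compound 2 `Cc1cc(C)c(CN2CCc3ccc(-c4c(C)noc4C)c(Cl)c3C2=O)c(=O)[nH]1` gives 105 nM, the lowest of the three numbers measured so far: compound 3 `Cc1cc(C)c(CN2CCc3c(C)cc(O[C@@H]4CCOC4)c(Cl)c3C2=O)c(=O)[nH]1` gives 290 nM, and compound 1 `Cc1cc(C)c(CN2CCc3c(F)cc(O[C@@H]4CCOC4)c(Cl)c3C2=O)c(=O)[nH]1` gives 994 nM. Compound 4 `Cc1cc(C)c(CN2CCc3c(Cl)cc(-c4c(C)noc4C)c(Cl)c3C2=O)c(=O)[nH]1` differs from compound 2 in one place: chloro in place of hydrogen on an aromatic carbon. Among the compounds with values here, the one measured step that touches the same aromatic carbon is a 3.4-fold lower number from compound 1 to compound 3 (0.53 log units; beyond the scatter), which shows that the group there can shift the number, yet no measured pair swaps hydrogen for chloro, so the direction is open. The step expected in this assay is therefore a 1.1-fold higher number from compound 2 to compound 4 (0.06 log units; within the scatter), within the usual scatter. Compound 4 is estimated at 120 nM, with a range from 40 nM to 360 nM.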

Compound 4, half-maximal inhibitory concentration: 15 nM
For compound 4 the middle estimate is 8.0-fold (0.90 log units) above the measured one, outside the stated range (below it).
By their numbers in this assay, from the lowest: compound 4; then compound 2; then compound 3; then compound 1.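

In this assay, chloro in place of hydrogen gives a 7.0-fold lower number from compound 2 to compound 4 (0.85 log units; beyond the scatter), so the direction of this swap at this aromatic carbon, ortho to a fused ring, is now known. The number also falls in a 3.4-fold lower number from compound 1 to compound 3 (0.53 log units; beyond the scatter), but this new step shows a drop with the 3,5-dimethyl-1,2-oxazol-4-yl group on the ring. Nothing available explains the drop. Still open, going by these compounds, is whether bromo, methoxy or a nitrile at this carbon would lower the number further. Also open, on these data alone, is how methyl or fluoro there would compare with chloro alongside the 3,5-dimethyl-1,2-oxazol-4-yl group.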